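The source may report more compounds than this note shows. Statements on the series, on what has been measured and on what is new or still open speak of the compounds shown alone.

Measured compounds:

Compound 1, `CCCNC(=O)[C@@H]1C[C@H]2CCC[C@@H](C1)[C@@H]2NC(=O)c1cc2scnc2n1Cc1ccc(OC)cc1`, gives > 25000 nM.
Compound 2, `CCCNC(=O)[C@@H]1C[C@H]2CCC[C@@H](C1)[C@@H]2NC(=O)c1cc2sc(Br)nc2n1Cc1ccc(OC)cc1`, gives > 100000 nM.
Compound 3, `CCCNC(=O)C1CCN(C(=O)c2cc3cc(Br)ccc3n2Cc2ccc(OC)cc2)CC1`, gives > 100000 nM.

All three values come from an ADME assay on HEK-293T cells (Homo sapiens) for cytotoxicity, read by luminescence and CellTiter-Glo, with a stated time of 24 h; a higher number here means that more compound is tolerated, a lower number that less compound is tolerated. For compound 1 the value is a limit of the assay and not a number. For compound 2 the value is likewise a limit. For compound 3 the value is also a limit. Two of the three values sit at one limit of > 100000 nM in this assay, at which 2 of the 3 values shown sit, and one at another (the limit of > 25000 nM in this assay, at which 1 of the 3 values shown sits), so none of them is a measured midpoint.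

Compound 2 and compound 1 differ in one place: hydrogen in place of bromo on an aromatic carbon. That step, a step that the two limits leave unreadable from compound 2 to compound 1, cannot be read, since both ends are limits the limit of > 100000 nM in this assay, at which 2 of the 3 values shown sit (the limit of > 25000 nM in this assay, at which 1 of the 3 values shown sits).

Compound 3 carries a different core; how its core differs from that of compound 2 is not broken down here. Compound 4, `CCCNC(=O)C1CCN(C(=O)c2cc3ccccc3n2Cc2ccc(OC)cc2)CC1`, has not yet been measured in this assay. It differs from compound 3 by the same kind of change: hydrogen in place of bromo on an aromatic carbon. The surroundings differ, though: in compound 2 the bromo leaves a five-membered aromatic ring with one nitrogen and one sulfur, whereas in compound 3 it leaves a six-membered aromatic ring of carbon only.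

Among the compounds with values here, since compound 3 already sits at a limit (the limit of > 100000 nM in this assay, at which 2 of the 3 values shown sit), and the only readable comparison of the same kind is itself unreadable, compound 4 is expected to be tolerated to a similar extent, with an estimated step of a number no higher from compound 3 to compound 4 (the limit leaves the size open). The estimate for compound 4 in this assay is 100000 nM, between 40000 nM and 250000 nM.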

Compound 4, half-maximal cytotoxic concentration: 26000 nM
Compound 4: middle estimate off by 3.8-fold (0.59 log units), on the high side; the whole stated range lies above it.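

In this assay, replacing bromo with hydrogen on the aromatic carbon of the six-membered ring gives an at least 3.8-fold lower number from compound 3 to compound 4 (0.58 log units; beyond the scatter), so on the core of compound 3 the compound without bromo is tolerated at lower concentrations, and this change stands clear of the usual scatter. Compound 3 gives > 100000 nM, which is a limit and not a number, so this single pair shows that the step is real but leaves its full size open. The same replacement from compound 2 to compound 1 cannot be read, since both ends are limits; the result on the core of compound 3 therefore neither carries over to the core of compound 1 nor is contradicted by it, and one readable pair makes no rule for the series.

Still open, from the compounds shown here alone, is whether removing bromo lowers the number on the core of compound 1 at all, which would take real values at both ends of that pair. Going by these compounds, only bromo and hydrogen appear on this aromatic carbon, so it also remains open whether a chloro group, a methyl group or an amine there would behave like bromo or like hydrogen in this assay.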